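The source may report more compounds than this note shows. Statements on the series, on what has been measured and on what is new or still open speak of the compounds shown alone.

Measured so far in a physicochemical assay for lipophilicity, measured as octanol-water partition; a higher number here means a more lipophilic compound, a lower number a more polar compound:
compound 1, `O=C(COc1cccc2ccccc12)N/N=C/c1ccc(O)cc1`: 3.73
compound 2, `C/C(=N\NC(=O)COc1cccc2ccccc12)c1ccccc1`: 3.65
compound 3, `C/C(=N\NC(=O)COc1cccc2ccccc12)c1ccc(Br)cc1`: 3.61

In this assay compound 1 has the highest of the three numbers, but its gaps to compound 2 and to compound 3 both lie within the scatter, so the three are effectively level. Among the measured compounds shown here, the only single change measured among them is a number 0.04 log units lower from compound 2 to compound 3 (within the scatter), which concerns an aromatic carbon and says little about a change at an oxygen. Compound 4, `COc1ccc(/C=N/NC(=O)COc2cccc3ccccc23)cc1`, differs from compound 1 by methyl in place of hydrogen on an oxygen on an aromatic ring, hydroxy becoming methoxy. For the measured compounds named here, no measured step covers this swap, so the expectation rests on the one carbon entering. Compound 4 is expected at 4, between 3.6 and 4.4, an estimated step of a number 0.27 log units higher from compound 1 to compound 4 (within the scatter) that may only just clear the scatter.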

Compound 4, partition coefficient: 3.77
The estimate for compound 4 lay 0.23 log units above the measured number; the range from low to high includes it.
By their numbers in this assay, from the lowest: compounds 3, 2, 1 and 4 (each within the scatter of the next).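

In this assay, putting methyl in place of hydrogen on the oxygen on the aromatic ring, turning 4-hydroxyphenyl into 4-methoxyphenyl, gives a number 0.04 log units higher from compound 1 to compound 4 (within the scatter) and so no clear change. Among the compounds shown here, this is the first measured swap at this oxygen, and here the added carbon leaves the two compounds level. Nothing at hand explains why.

From the compounds shown here alone, whether a longer chain on this oxygen, such as propyl, or an amine in place of the hydroxy would give a step beyond the scatter remains open.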